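Moving the ring nitrogen on a fatty-acid amide hydrolase inhibitor

A few compounds are considered here, and "the series" means these few. Any claim that something is new, unique, unknown or untested is made for them only; others in the source may bear on it.

Measured compounds:
- compound 1 `O=C(CCCCCCc1ccccc1)c1nc(Br)co1`: 3 nM
- compound 2 `CSc1coc(C(=O)CCCCCCc2ccccc2)n1`: 29 nM
- compound 3 `O=C(CCCCCCc1ccccc1)c1nc(-c2cccnc2)co1`: 18 nM

All three were tested in an assay on isolated protein for inhibition of Fatty-acid amide hydrolase 1 (Rattus norvegicus); on this read-out lower numbers stand for stronger inhibition and higher numbers for weaker inhibition. Compound 3 gives 18 nM, the second highest of the three numbers. Its nearest neighbour is compound 2, whose number lies within the scatter of it; compound 1 stands further away, with a 6.0-fold higher number from compound 1 to compound 3 (0.78 log units; beyond the scatter).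

The next compound, compound 4 `O=C(CCCCCCc1ccccc1)c1nc(-c2ccncc2)co1`, keeps the shared core and the long chain but changes one group: pyridin-4-yl in place of pyridin-3-yl on an aromatic carbon. For the measured compounds named here, none of the measured steps swaps one pyridyl ring for another, so no direct precedent exists. The step of a 1.6-fold lower number from compound 2 to compound 3 (0.21 log units; within the scatter) shows that exchanging one group at this position for a pyridin-3-yl ring left the number within the scatter, while a 9.7-fold higher number from compound 1 to compound 2 (0.99 log units; beyond the scatter) and a 6.0-fold higher number from compound 1 to compound 3 (0.78 log units; beyond the scatter) show that leaving bromo costs a modest amount. Shifting the nitrogen within the ring is expected to change little, so for compound 4 a step of a 1.1-fold higher number from compound 3 to compound 4 (0.05 log units; within the scatter) is expected, within the scatter. Compound 4 is therefore estimated at 20 nM, within a range of 7 nM to 60 nM.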

Compound 4, inhibition constant: 1.6 nM
For compound 4 the middle estimate is 13-fold (1.10 log units) above the measured one; measured number below the stated range.
By their numbers in this assay, from the lowest: compounds 4 and 1 (each within the scatter of the next); then compounds 3 and 2 (each within the scatter of the next).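

For the compounds shown here, at this position, where the nitrogen sits within the pyridyl ring matters far more than the earlier compounds could show: an 11-fold lower number from compound 3 to compound 4 (1.05 log units; beyond the scatter) separates two groups with the same atoms, joined differently. Pyridin-4-yl also stands well apart from methylsulfanyl, with an 18-fold lower number from compound 2 to compound 4 (1.26 log units; beyond the scatter) in this assay, whereas the pyridin-3-yl ring had not. Replacing bromo here therefore carries no fixed cost: the steps from compound 1 to compound 2 and compound 3 both lie beyond the scatter, against a 1.9-fold lower number from compound 1 to compound 4 (0.27 log units; within the scatter).

Nothing shown here accounts for the effect of moving the nitrogen. On these data alone, it remains open how a pyridin-2-yl ring would compare, and whether an amine or a carboxylic acid on the pyridin-4-yl ring would preserve this result.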